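The source may hold more compounds than are shown below. What is called first, only, known or untested is meant among the compounds shown, and "the series" means these compounds.

Measured compounds:
compound 1 `COc1cccc(/C=C/C(=O)Nc2cc(OC)c(OC)c(OC)c2)c1`, 2100 nM
compound 2 `COc1ccc(C(=O)c2cc(OC)c(OC)c(OC)c2)cc1NC(=O)/C=C/c1ccc(OC)c(OC)c1`, 7500 nM

Both were tested in a functional assay on PC-3 cells (Homo sapiens) for cytotoxicity, read by MTT assay, with a stated time of 72 h; on this read-out lower numbers stand for stronger inhibition and higher numbers for weaker inhibition. Compound 2 has the highest number of the two, and compound 1, its nearest neighbour, sits a stretch below it that lies beyond the usual scatter. Compound 3 `C#CCOc1cccc(/C=C/C(=O)Nc2cc(C(=O)c3cc(OC)c(OC)c(OC)c3)ccc2OC)c1` has not been measured yet. It differs from compound 2 in one place: 3-(propargyloxy)phenyl in place of 3,4-dimethoxyphenyl on a double-bonded chain carbon bound to a double-bonded chain carbon. Within the data shown here, no step between measured compounds covers this exchange, so there is nothing to lean on directly. Compound 1, which carries a single methoxy on the same kind of ring as the cinnamamide partner, gives 2100 nM on a different core, which at most hints that one oxygen on that ring need not hurt. Compound 3 is therefore expected to fall near compound 2 or somewhat lower, with the step of a 1.7-fold lower number from compound 2 to compound 3 (0.22 log units; within the scatter) estimated as modest; its estimated value is 4500 nM, within 1200 nM to 16000 nM.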

Compound 3, half-maximal inhibitory concentration: 13100 nM
Estimate against measurement, compound 3: 2.9-fold (0.46 log units) below, and the stated range covers the measured number.
By their numbers in this assay, from the lowest: compound 1; then compounds 2 and 3 (each within the scatter of the next).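

In this assay, among these compounds, the exchange of 3,4-dimethoxyphenyl for 3-(propargyloxy)phenyl on a double-bonded chain carbon bound to a double-bonded chain carbon gives a 1.7-fold higher number from compound 2 to compound 3 (0.24 log units; within the scatter) and is the only direct reading of this position, where the two groups cannot be told apart. The entering group carries one hydrogen-bond acceptor in place of two and adds a triple bond outside aromatic rings, yet the two compounds stay within the scatter of each other on this read-out. No measurement is available that would explain this result or assign a property to either group. The compounds shown leave open whether an amine or a carboxylic acid on this ring would move the number beyond the scatter. They also leave open how a longer chain on the ring oxygen would read, and whether the exchange would give a similar step on the core of compound 1.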